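This account rests on a few compounds, and the source may have more. Where it says the series, first, only, none or still open, it means among the compounds named here.

Among the compounds with values here, compound 2 `Clc1ccc(CO/N=C/c2c(-c3cccc4ccccc34)nc3sccn23)cc1Cl` holds the lower of the two numbers so far in an assay on HepG2 cells for agonist activity at nuclear receptor subfamily 1 group I member 3 (Homo sapiens), read by a luciferase reporter, with a stated time of 23 h; on this read-out higher numbers stand for an effect only at larger amounts of compound and lower numbers for an effect already at smaller amounts: compound 2 gives 940 nM, while compound 1 `COc1ccc(CO/N=C/c2c(-c3ccc4ccccc4c3)nc3occn23)cc1` gives 4400 nM, a gap beyond the usual scatter. Compound 1 and compound 2 differ in more than one place, so their two values show only that much. The move to compound 3 `CC(C)(C)c1ccc(-c2nc3sccn3c2/C=N/OCc2ccc(Cl)c(Cl)c2)cc1` is a single change: 4-(tert-butyl)phenyl in place of naphthalen-1-yl on an aromatic carbon. Within the data shown here, no measured pair isolates this change, so its direction rests on judgment alone. Because compound 2 already stands at 940 nM with its naphthalen-1-yl group, the switch to 4-(tert-butyl)phenyl is expected to leave the number near where it is or lower it modestly. The step expected from this change is a 1.9-fold lower number from compound 2 to compound 3 (0.27 log units; within the scatter). Compound 3 is therefore estimated at 500 nM, with a range from 150 nM to 2000 nM.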

Compound 3, half-maximal effective concentration: 2400 nM
Compound 3: the middle estimate sits 4.8-fold (0.68 log units) below what was measured; measured number outside the range, above it.
By their numbers in this assay, from the lowest: compound 2; then compounds 3 and 1 (each within the scatter of the next).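

In this assay, within the data shown here, the exchange of naphthalen-1-yl for 4-(tert-butyl)phenyl on this aromatic carbon gives a 2.6-fold higher number from compound 2 to compound 3 (0.41 log units; beyond the scatter), the first step that comes from a single change. It shows that this position responds to the identity of its group even when the count stays the same: both groups have 10 heavy atoms, all carbon, with no hydrogen-bond donors or acceptors and no net charge, and they differ in having two aromatic rings or one. Nothing available explains why the number moves this way.

The compounds shown leave open how an unsubstituted phenyl, a pyridine or a carboxylic acid would fare at this position. They also leave open whether the naphthalen-2-yl of compound 1 would match naphthalen-1-yl on the core of compound 2.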